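The source may report more compounds than this note shows. Statements on the series, on what has been measured and on what is new or still open speak of the compounds shown alone.

In a functional assay on Jurkat cells (Homo sapiens) for antiproliferative activity, read by MTT assay, with a stated time of 72 h (on this read-out higher numbers stand for weaker inhibition and lower numbers for stronger inhibition), compound 1 `COc1ccc(-c2c(C(=O)c3cc(OC)c(OC)c(OC)c3)sc3ccccc23)cc1` gives 1600 nM. Compound 2 `COc1ccc(OC)c(-c2c(C(=O)c3cc(OC)c(OC)c(OC)c3)sc3ccccc23)c1` reads > 10000 nM, which is a limit and not a number. This is the limit of > 10000 nM in this assay, at which 1 of the 2 values shown sits, so compound 2 has no exact position on the scale. Among the compounds with values here, only one measured step bears on the next change: an at least 6.2-fold higher number from compound 1 to compound 2 (0.79 log units; beyond the scatter), seen when 2,5-dimethoxyphenyl replaced 4-methoxyphenyl on an aromatic carbon.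

Compound 3 `COc1ccc(-c2c(C(=O)c3cc(OC)c(OC)c(OC)c3)sc3ccccc23)cc1C` carries 4-methoxy-3-methylphenyl in place of 2,5-dimethoxyphenyl on that same carbon, and the count of the change is 4-methoxy-3-methylphenyl in place of 2,5-dimethoxyphenyl on an aromatic carbon. The new group keeps the 4-methoxy of compound 1, so a result closer to that of compound 1, at 1600 nM, is expected. Within the data shown here, no measured step shows what the methyl group does, which leaves the range wide and allows for weaker inhibition than in compound 1.

In this assay, the expected step is an at least 4.0-fold lower number from compound 2 to compound 3 (0.60 log units; beyond the scatter), in the direction of stronger inhibition. For compound 3 the estimated value is 2500 nM, with an expected range from 700 nM to 9000 nM.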

Compound 3, half-maximal inhibitory concentration: > 10000 nM
Compound 3 ended at the assay's limit (the forecaster's own chance of this, stated with the estimate: 15%); at least 4.0-fold (0.60 log units) between middle value and limit.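

Adding one methyl group to the 4-methoxyphenyl of compound 1 gives an at least 6.2-fold higher number from compound 1 to compound 3 (0.79 log units; beyond the scatter) in this assay. Keeping the 4-methoxy group is therefore not enough to keep the measurable inhibition seen for compound 1, and a change as small as methyl in place of hydrogen on an aromatic carbon of this ring makes the difference. Compound 2 and compound 3 both end at a limit and not at a number, so the step between them cannot be read and neither can be placed above the other: the limit of > 10000 nM in this assay, at which 2 of the 3 values shown sit.

How far compound 3 lies from compound 1 stays open, since its limit gives only a minimum size for the step, and nothing here explains why the methyl group has this effect. Also open, as far as these compounds go, is whether a fluorine atom, a hydroxyl group or an amine in place of that methyl group would keep the inhibition of compound 1 or lose it as well.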